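Exchanging Chloro for Methoxy on the Anilide Ring

The compounds below may be only part of what the source reports. "The series", "measured", "known", "first", "only" and "open" are said of these compounds alone.

Compound 2 `Cc1occc1-c1nnc(SCC(=O)Nc2ccc(Cl)cc2)n1Cc1ccco1` carries a 4-chlorophenyl group on the amide nitrogen of the shared core. In a functional assay on CHO cells for antagonist activity at Orexin/Hypocretin receptor type 1 (Homo sapiens), read by FLIPR and calcium flux (on this read-out lower numbers stand for stronger inhibition and higher numbers for weaker inhibition), compound 2 gives 2000 nM, the only plain number among the results shown. Compound 1 `Cc1cccc(C)c1NC(=O)CSc1nnc(-c2ccoc2C)n1Cc1ccco1`, which bears 2,6-dimethylphenyl in that position, shows in this assay > 15800 nM, which is a limit of the assay and not a number (the limit of > 15800 nM in this assay, at which 1 of the 2 values shown sits). Within the data shown here, the one measured step, an at least 7.9-fold lower number from compound 1 to compound 2 (0.89 log units; beyond the scatter), thus shows that the ring on the amide nitrogen has a strong say in the result.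

Compound 3 `COc1ccc(NC(=O)CSc2nnc(-c3ccoc3C)n2Cc2ccco2)cc1` is not yet measured. It differs from compound 2 only in methoxy in place of chloro on an aromatic carbon. Among the measured compounds shown here, no measured step exchanges one substituent on this ring for another, so an at least 7.9-fold lower number from compound 1 to compound 2 (0.89 log units; beyond the scatter) gives only a loose guide: altering this ring can move the number far, yet its direction here is open. For compound 3 a modest rise in the number, towards weaker inhibition, is expected, a 1.8-fold higher number from compound 2 to compound 3 (0.24 log units; within the scatter). The estimate for compound 3 in this assay is 3500 nM, within a range from 1000 nM to 15000 nM.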

Compound 3, inhibition constant: > 15800 nM
Compound 3 gave a limit, no number; the forecaster's own chance of this, stated with the estimate: 25%; middle value at least 4.5-fold (0.65 log units) away from the limit.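

The exchange of a single group on the ring, with everything else held the same, matters in this assay: methoxy in place of chloro gives an at least 7.9-fold higher number from compound 2 to compound 3 (0.89 log units; beyond the scatter), a step beyond the scatter. Among these compounds, the earlier step changed the substitution of the ring as a whole, whereas this one shows that the ring being a 4-substituted phenyl is not enough, and that the identity of the one group on it decides whether a plain number is seen at all, with 4-chlorophenyl the only case among the three compounds that gives one. Compound 1 and compound 3 both stand at a limit of the assay and not at a number, so the step between them cannot be read: the limit of > 15800 nM in this assay, at which 2 of the 3 values shown sit.

From the compounds shown here alone, how much higher the number of compound 3 really lies stays open, so the full size of this step is unknown. Also open, going by these compounds, is whether chloro is needed here, or whether fluoro, bromo, methyl, an amine or a carboxylic acid on the same aromatic carbon would match or improve on compound 2.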